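The compounds below may be only part of what the source reports. "The series", "measured", "known", "first", "only" and "open" are said of these compounds alone.

Two compounds of this series have numbers in an assay on membranes from HEK293 cells for displacement of a labelled ligand from adenosine receptor A2b (Homo sapiens), read by scintillation counting, with a stated time of 30 min, tested at 1 uM; on this read-out lower numbers stand for less inhibition and higher numbers for more inhibition at the one concentration tested (going by the name of the read-out). Compound 1 `CC(=O)C1=C(C)NC(=O)NC1c1ccsc1` gives 24%. Compound 2 `CCSC(=O)C1=C(C)NC(=O)NC1c1ccco1` gives 29%. Compound 2 holds the higher of the two numbers, yet its gap to compound 1 lies within the usual scatter, so no order between the two can be read from these values.

Compound 3 `CCSC(=O)C1=C(C)NC(=O)NC1c1ccsc1` has not yet been measured in this assay. Relative to compound 2 the change is thiophen-3-yl in place of furan-2-yl on a saturated ring carbon. Within the data shown here, no measured pair differs only in this way, so no measured step gives a direction. Compound 1 carries the same thiophen-3-yl group as compound 3 but differs from compound 2 at a second place too, and its value sits within the scatter of compound 2. A step of no change at the digits printed from compound 2 to compound 3 (within the scatter) is therefore expected, that is, none beyond the scatter. For compound 3 the expected inhibition in this assay is 29%, with a range from 14% to 44%.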

Compound 3, a percentage reported as inhibition, at one concentration (the size of the read-out at that concentration, not a potency): 17%
For compound 3 the middle estimate is 12 percentage points above the measured one, and the stated range covers the measured number.
By their numbers in this assay, from the lowest: compounds 3, 1 and 2 (each within the scatter of the next, the first and the last beyond it).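

Among these compounds, the change of furan-2-yl to thiophen-3-yl on the saturated ring carbon gives a number 12 percentage points lower from compound 2 to compound 3 (beyond the scatter) in this assay and is the first one-place step at this position, showing that the two rings are not interchangeable when the (ethylsulfanyl)carbonyl group is present. With thiophen-3-yl held constant, ethylsulfanyl in place of methyl on the carbonyl carbon gives a number 7 percentage points lower from compound 1 to compound 3 (within the scatter) and so shows no readable effect of that change. No measurement here bears on the reason for the ring step.

The compounds shown do not separate the identity of the ring hetero atom from its point of attachment, as furan-3-yl or thiophen-2-yl would. As far as these compounds go, how a phenyl group at this position or a longer chain in place of ethylsulfanyl would read also remains open.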